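Two Amides at the Limit and an Untested Hybrid

This account rests on a few compounds, and the source may have more. Where it says the series, first, only, none or still open, it means among the compounds named here.

Compound 1 `C=CC1=C(C(=O)NC(C)(C)C)C(c2ccc(OC)cc2)OC1`: > 100000 nM
Compound 2 `C=CC1=C(C(=O)Nc2ccccc2OC)C(c2ccc(F)cc2)OC1`: > 100000 nM

Both measured compounds were tested in a functional assay on SW480 cells (Homo sapiens) for cytotoxicity, read by MTT assay, with a stated time of 24 h; on this read-out higher numbers stand for weaker inhibition and lower numbers for stronger inhibition. For compound 1 the value > 100000 nM is a limit of the assay rather than a number. For compound 2 the value > 100000 nM is likewise a limit rather than a number. Among the compounds with values here, compound 2 therefore stands at the edge of what this assay can report, and it shares that position with the only other compound measured, as the limit of > 100000 nM in this assay, at which 2 of the 2 values shown sit, shows. Within the data shown here, no step between two measured compounds can be drawn from these data.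

The untested compound 3 `C=CC1=C(C(=O)NC(C)(C)C)C(c2ccc(F)cc2)OC1` keeps the rest of compound 2 and changes only the amide: tert-butyl in place of 2-methoxyphenyl on an amide-type nitrogen. The same tert-butyl amide is already present in compound 1, which also sits at the limit. Because the two measured neighbours both sit at the limit of > 100000 nM in this assay, at which 2 of the 2 values shown sit, no measurable change is expected on this step. The step of a number no higher from compound 2 to compound 3 (the limit leaves the size open) is expected to be none beyond the scatter. Compound 3 is estimated at 100000 nM in this assay, with a range from 40000 nM to 300000 nM, and it is expected that this assay will most likely again report only a limit.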

Compound 3, half-maximal inhibitory concentration: > 100000 nM
Compound 3: a limit, no number; the forecaster's own chance of this, stated with the estimate: 85%; the middle value sits exactly at the limit.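

In this assay, within the data shown here, compound 3 gives > 100000 nM as a limit of the assay and not a number, so no step from compound 1 or compound 2 to compound 3 can be read. All three compounds share one position: the limit of > 100000 nM in this assay, at which 3 of the 3 values shown sit. The compounds shown leave open how strongly each acts and whether either change alters that.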